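The compounds below may be only part of what the source reports. "The series", "measured", "known", "first", "only" and "open" are said of these compounds alone.

Compound 1 `CCN(CC)C(=O)Cc1c(-c2ccc(OCc3ccccc3)cc2)nn2c(C)cc(C)nc12` gives 0.99 nM in an assay on isolated protein (kidney, strain Wistar) for displacement of a labelled ligand from Translocator protein (Rattus norvegicus), read by scintillation counting, with a stated time of 90 min (on this read-out lower numbers stand for stronger inhibition and higher numbers for weaker inhibition), the highest of the three numbers in hand. Compound 2 `CCN(CC)C(=O)Cc1c(-c2ccc(OCc3cccc(F)c3)cc2)nn2c(C)cc(C)nc12` gives 0.47 nM and compound 3 `CCN(CC)C(=O)Cc1c(-c2ccc(OCc3cccc(C(F)(F)F)c3)cc2)nn2c(C)cc(C)nc12` gives 0.67 nM. Both measured steps from compound 1 change only a substituent on the benzyloxy group: a 2.1-fold lower number from compound 1 to compound 2 (0.32 log units; beyond the scatter) and a 1.5-fold lower number from compound 1 to compound 3 (0.17 log units; within the scatter). Compound 4 `CCN(CC)C(=O)Cc1c(-c2ccc(OCCc3ccccc3)cc2)nn2c(C)cc(C)nc12` differs in another way, (benzyl in place of phenyl on a saturated chain carbon bound to an oxygen on an aromatic ring), that is, benzyloxy becomes phenethyloxy. Among the compounds with values here, no measured step touches this chain, so the substituent steps offer no direct guide; they show only that the benzyloxy group tolerates modest variation. The step from compound 1 to compound 4 is therefore expected to be small, a 2.0-fold higher number from compound 1 to compound 4 (0.31 log units; beyond the scatter), if anything toward a higher number. Compound 4 is estimated at 2 nM, with a range of 0.5 nM to 8 nM.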

Compound 4, inhibition constant: 0.13 nM
Compound 4: middle estimate off by 15-fold (1.19 log units), on the high side; measured number outside the range, below it.
By their numbers in this assay, from the lowest: compound 4; then compounds 2, 3 and 1 (each within the scatter of the next, the first and the last beyond it).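

Phenethyloxy in place of benzyloxy gives a 7.6-fold lower number from compound 1 to compound 4 (0.88 log units; beyond the scatter) in this assay, so this chain, untouched by the substituent steps, is a place where the number moves further than it did for fluoro or trifluoromethyl. The phenethyloxy chain also stands clear of both substituted benzyloxy groups, with a 3.6-fold lower number from compound 2 to compound 4 (0.56 log units; beyond the scatter) and a 5.2-fold lower number from compound 3 to compound 4 (0.71 log units; beyond the scatter) as its steps. Nothing measured here accounts for this change. Open, from the compounds shown here alone, is whether a longer chain such as phenylpropyloxy moves the number further, and whether fluoro or trifluoromethyl on the phenethyloxy ring adds to the step.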